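A few compounds are considered here, and "the series" means these few. Any claim that something is new, unique, unknown or untested is made for them only; others in the source may bear on it.

Series notes. Compound 2 `NC(=O)c1cnc2c(c1Cl)CCN2` gives 92 nM in an assay on isolated protein for inhibition of Nicotinamide N-methyltransferase (Homo sapiens), read by luminescence, with a stated time of 20 min (a lower number here means a stronger inhibitor, a higher number a weaker inhibitor), the lowest of the three numbers recorded. Compound 3 `NC(=O)c1cnc2c(c1)CCN2` gives 175 nM in this assay, and compound 1 `C[C@@H]1Cc2cc(C(N)=O)c[n+](C)c2N1` gives 6240 nM. Among the measured compounds shown here, the only single-point step recorded is a 1.9-fold higher number from compound 2 to compound 3 (0.28 log units; within the scatter). Compound 4 `C[C@@H]1Cc2c(ncc(C(N)=O)c2Cl)N1` differs from compound 2 by methyl in place of hydrogen on a saturated ring carbon, on a saturated ring carbon of the five-membered non-aromatic ring, next to the ring nitrogen. For the measured compounds named here, no measured step isolates this change: compound 1 also carries a methyl on that carbon, but it differs from compound 3 in more than one place, so the gap between the values of compound 1 and compound 3 cannot be assigned to the methyl alone. The step from compound 2 to compound 3 concerns a different position and was within the scatter. A small step in this assay is therefore expected, a modest rise being somewhat more likely than a fall. For compound 4 the expected step is a 1.7-fold higher number from compound 2 to compound 4 (0.24 log units; within the scatter). Compound 4 is estimated at 160 nM, with a range from 50 nM to 500 nM.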

Compound 4, half-maximal inhibitory concentration: 48 nM
Compound 4: the middle estimate sits 3.3-fold (0.52 log units) above what was measured, outside the stated range (below it).
By their numbers in this assay, from the lowest: compounds 4, 2 and 3 (each within the scatter of the next, the first and the last beyond it); then compound 1.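

Among the compounds shown here, this is the first direct reading of methyl in place of hydrogen on a saturated ring carbon, next to the ring nitrogen: this assay shows a 1.9-fold lower number from compound 2 to compound 4 (0.28 log units; within the scatter). With the chloro present, this position therefore accepts a methyl, and compound 2 and compound 4 cannot be told apart in this measurement. Nothing available gives a reason for this result.

From the compounds shown here alone, whether the methyl behaves the same way on the core of compound 3, without the chloro, remains open, as does the result for the opposite configuration at this carbon. Also open, going by these compounds, is whether an ethyl, a hydroxymethyl or an aminomethyl group on the same carbon would keep the number in this range.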